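This account rests on a few compounds, and the source may have more. Where it says the series, first, only, none or still open, it means among the compounds named here.

Going by the values given here, compound 2 `COc1ccc(NC(=O)CN2CCN(c3nnc(Cc4ccccc4)c4ccccc34)CC2)cc1OC` is one of three compounds measured in a functional assay on HT-29 cells (Homo sapiens) for cytotoxicity, read by MTT assay, with a stated time of 72 h; on this read-out higher numbers stand for weaker inhibition and lower numbers for stronger inhibition. Compound 2 gives 145000 nM, the highest of the three numbers. Compound 1 `Cc1cccc(Cl)c1NC(=O)CN1CCN(c2nnc(Cc3ccncc3)c3ccccc23)CC1` gives 22600 nM, and compound 3 `O=C(CN1CCN(c2nnc(Cc3ccncc3)c3ccccc23)CC1)Nc1cccc(Br)c1` gives 1350 nM. Among the compounds with values here, no single-point step joins compound 2 to either of them; the one step measured in one place is a 17-fold lower number from compound 1 to compound 3 (1.22 log units; beyond the scatter), a large move toward stronger inhibition when a bromophenyl group takes the place of a more crowded phenyl group on the amide-type nitrogen.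

Compound 4 `O=C(CN1CCN(c2nnc(Cc3ccccc3)c3ccccc23)CC1)Nc1ccc(Br)cc1` differs from compound 2 in the same region: 4-bromophenyl in place of 3,4-dimethoxyphenyl on an amide-type nitrogen. Within the data shown here, the step from compound 1 to compound 3 is the only guide, and it concerns a bromophenyl entering at the same amide-type nitrogen, though with a different core and a different bromine position, so it bears on the present change only loosely. On that basis a clear drop in the number is expected, though smaller and less certain than the measured step. Compound 4 is therefore expected to give about 12000 nM, with a likely range from 2500 nM to 60000 nM, an estimated change of a 12-fold lower number from compound 2 to compound 4 (1.08 log units; beyond the scatter).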

Compound 4, half-maximal inhibitory concentration: 60200 nM
Compound 4: the middle estimate sits 5.0-fold (0.70 log units) below what was measured; the whole stated range lies below it.
By their numbers in this assay, from the lowest: compound 3; then compound 1; then compound 4; then compound 2.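

In this assay, replacing 3,4-dimethoxyphenyl with 4-bromophenyl on the amide-type nitrogen gives only a modest gain, a 2.4-fold lower number from compound 2 to compound 4 (0.38 log units; beyond the scatter). A bromophenyl group entering at this nitrogen therefore does not bring a large step in every setting, although the earlier step, a 17-fold lower number from compound 1 to compound 3 (1.22 log units; beyond the scatter), was large; the two pairs differ in the group that leaves, the bromine position and the core. Nothing available here accounts for the difference in size between these two steps.

From the compounds shown here alone, compound 3 and compound 4 differ in more than one place, so the separate contributions of the bromine position and the core remain open. Also open, going by these compounds, is how the number would respond to a phenyl group carrying an amine or a carboxylic acid on this nitrogen.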